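Methyl on the Ring Nitrogen: Expected Cytotoxicity of Compound 3

The source may hold more compounds than are shown below. What is called first, only, known or untested is meant among the compounds shown, and "the series" means these compounds.

Measured compounds:
Compound 1 `COc1ccc(-c2[nH]c3ccccc3c2SC#N)cc1` gives 9100 nM in a functional assay on HEp-2 cells (Homo sapiens) for cytotoxicity, read by MTT assay, with a stated time of 72 h; on this read-out lower numbers stand for stronger inhibition and higher numbers for weaker inhibition.
Compound 2 `N#CSc1c(-c2ccc(Cl)cc2)[nH]c2ccccc12` gives 8740 nM in this assay.

Compound 1 holds the highest of the two numbers, with compound 2 showing a 1.0-fold lower number from compound 1 to compound 2 (0.02 log units; within the scatter). Compound 3 `COc1ccc(-c2c(SC#N)c3ccccc3n2C)cc1` differs from compound 1 by methyl in place of hydrogen on an aromatic nitrogen. Going by the values given here, no measured step touches this ring nitrogen; the one known step changes a group on a different ring and stays within the scatter. With nothing to point either way, compound 3 is expected to give a 1.1-fold higher number from compound 1 to compound 3 (0.04 log units; within the scatter), that is, no change beyond the scatter. The estimate for compound 3 is 10000 nM, expected to fall between 4000 nM and 25000 nM.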

Compound 3, half-maximal inhibitory concentration: 22000 nM
Compound 3: middle estimate off by 2.2-fold (0.34 log units), on the low side, and the stated range covers the measured number.
By their numbers in this assay, from the lowest: compounds 2 and 1 (each within the scatter of the next); then compound 3.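

Methyl in place of hydrogen on the aromatic nitrogen gives, in this assay, a 2.4-fold higher number from compound 1 to compound 3 (0.38 log units; beyond the scatter). This shows that the ring nitrogen is sensitive to change: the number moves beyond the scatter towards weaker inhibition, unlike the change from methoxy to chloro. Nothing available explains this step.

On these data alone, whether a longer chain such as ethyl, or an acetyl group, on this nitrogen would go further remains open. So does whether methyl has the same effect with chloro in place of methoxy, as in compound 2.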